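The compounds below may be only part of what the source reports. "The series", "measured", "known", "first", "only" and "open" are said of these compounds alone.

Measured so far:
compound 1, `COc1ccc(-c2cc(N)c(C(=O)c3cc(OC)c(OC)c(OC)c3)s2)cc1OC`, 40 nM in a functional assay on L1210 cells (Mus musculus) for antiproliferative activity; on this read-out lower numbers stand for stronger inhibition and higher numbers for weaker inhibition
compound 2, `COc1cc(C(=O)c2sc(-c3ccc([N+](=O)[O-])cc3)cc2N)cc(OC)c1OC`, 100 nM in this assay

Compound 1 has the lowest number of the two. Among the compounds with values here, its single neighbour, compound 2, is reached by a 2.5-fold higher number from compound 1 to compound 2 (0.40 log units; beyond the scatter). Compound 3, `CCOc1ccc(-c2cc(N)c(C(=O)c3cc(OC)c(OC)c(OC)c3)s2)cc1`, is not yet measured. It differs from compound 1 by 4-ethoxyphenyl in place of 3,4-dimethoxyphenyl on an aromatic carbon. Within the data shown here, the step to compound 2 is the only one that changes the same aryl group, and it was modest; the change to compound 3 keeps an alkoxy-bearing ring, so little movement beyond the scatter is expected. The expected result for compound 3 is 30 nM, between 8 nM and 120 nM, meaning an estimated step of a 1.3-fold lower number from compound 1 to compound 3 (0.12 log units; within the scatter).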

Compound 3, half-maximal inhibitory concentration: 590 nM
Compound 3: middle estimate off by 20-fold (1.29 log units), on the low side; the whole stated range lies below it.
By their numbers in this assay, from the lowest: compound 1; then compound 2; then compound 3.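

In this assay, the aryl group on the carbon next to the ring sulfur proves more sensitive than the first step suggested: keeping an alkoxy-bearing ring still gives a 15-fold higher number from compound 1 to compound 3 (1.17 log units; beyond the scatter) and the step is large. Replacing nitro with ethoxy also gives a 5.9-fold higher number from compound 2 to compound 3 (0.77 log units; beyond the scatter), so having an alkoxy group on this ring does not by itself preserve activity. Nothing available explains this loss.

Compound 3 differs from compound 1 in both the number of ring oxygens and the ethoxy chain, and these two changes remain unseparated. A 4-methoxyphenyl group or a 3-methoxyphenyl group could tell them apart.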